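From Cyclohexylamino to Pyrrolidinyl: Expecting Another Limit

A few compounds are considered here, and "the series" means these few. Any claim that something is new, unique, unknown or untested is made for them only; others in the source may bear on it.

Two compounds share one core and differ only in the group on the amine nitrogen. Compound 1 `O=C1C=C(Nc2ccc(C(F)(F)F)cc2)C(=O)c2c1nc1n2[C@H]2OC[C@@H](O)[C@H]2OC1` carries 4-(trifluoromethyl)phenyl, and in a functional assay on ECa-109 cells for inhibition, with ECa-109 cell line (Homo sapiens) as the target, read by sulforhodamine B assay (on this read-out higher numbers stand for weaker inhibition and lower numbers for stronger inhibition), compound 1 gives 5500 nM. Compound 2 `O=C1C=C(NC2CCCCC2)C(=O)c2c1nc1n2[C@H]2OC[C@@H](O)[C@H]2OC1` carries cyclohexyl instead. In this assay compound 2 gives > 16000 nM, which is a limit of the assay and not a number. The step of an at least 2.9-fold higher number from compound 1 to compound 2 (0.46 log units; beyond the scatter) places compound 2 at the limit of > 16000 nM in this assay, at which 1 of the 2 values shown sits, the weaker end of what was measured. Compound 3 `O=C1C=C(N2CCCC2)C(=O)c2c1nc1n2[C@H]2OC[C@@H](O)[C@H]2OC1` has not been measured; it differs from compound 2 by pyrrolidin-1-yl in place of cyclohexylamino on a double-bonded ring carbon. No measured step covers this change, and the single step shown concerns a different group, so it guides only loosely. Compound 3 is expected to remain weak, with an estimated 20000 nM between 8000 nM and 50000 nM. The expected step that the limit leaves unreadable from compound 2 to compound 3 is estimated to stay within the scatter, and a limit rather than a number seems the likelier report.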

Compound 3, half-maximal inhibitory concentration: > 16000 nM
Compound 3 was reported as a limit; the forecaster's own chance of this, stated with the estimate: 70%; the middle value does not contradict the limit.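

Compound 2 and compound 3 are both reported only as limits, not as numbers, so no step between them can be read: the limit of > 16000 nM in this assay, at which 2 of the 3 values shown sit.

As far as these compounds go, whether cyclohexylamino and pyrrolidin-1-yl differ at all in their effect on the shared core remains open.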